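The source may hold more compounds than are shown below. What is called first, only, known or untested is meant among the compounds shown, and "the series" means these compounds.

Of the compounds shown here, three share one core and have been tested in an ADME assay on HEK293-A cells (Homo sapiens) for cytotoxicity, read by MTT assay, with a stated time of 48 h; a higher number here means a weaker inhibitor, a lower number a stronger inhibitor. Compound 1 `O=C1O[C@@H](CN2CCCCC2)CN1c1ccc(-n2cc(-c3ccccn3)cn2)c(F)c1` gives > 400 ug/mL, which is a limit of the assay rather than a number. Compound 2 `O=C1CCC(=O)N1C[C@H]1CN(c2ccc(-n3cc(-c4ccccn4)cn3)c(F)c2)C(=O)O1` gives > 400 ug/mL, again only a limit. Compound 3 `O=CNC[C@H]1CN(c2ccc(-n3cc(-c4ccccn4)cn3)c(F)c2)C(=O)O1` gives > 400 ug/mL, also a limit. Every value sits at the limit of > 400 ug/mL in this assay, at which 3 of the 3 values shown sit, so the steps a step that the two limits leave unreadable from compound 1 to compound 2 and a step that the two limits leave unreadable from compound 2 to compound 3 have no readable size. Compound 4 `CNC(=O)[C@H]1CN(c2ccc(-n3cc(-c4ccccn4)cn3)c(F)c2)C(=O)O1` has not yet been measured; it differs from compound 2 by methylcarbamoyl in place of (2,5-dioxopyrrolidin-1-yl)methyl on a saturated ring carbon, the leaving group carrying one five-membered non-aromatic ring and the entering group no ring. With both neighbouring steps unreadable, no shift beyond the scatter is expected in this assay. Compound 4 is therefore estimated to give 500 ug/mL, within 250 ug/mL to 1000 ug/mL. The step this estimate implies is a step that the limit leaves unreadable from compound 2 to compound 4.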

Compound 4, half-maximal inhibitory concentration: 342 ug/mL
The estimate for compound 4 lay 1.5-fold (0.16 log units) above the measured number, within the range that was stated.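

Methylcarbamoyl on this saturated ring carbon gives the first value in this assay that is a number and not a limit. The steps to it are an at least 1.1-fold lower number from compound 2 to compound 4 (0.06 log units; that floor lies within the scatter), an at least 1.1-fold lower number from compound 3 to compound 4 (0.06 log units; that floor lies within the scatter) and an at least 1.1-fold lower number from compound 1 to compound 4 (0.06 log units; that floor lies within the scatter), so no shift beyond the scatter is shown. The steps among the other three compounds still cannot be read: the limit of > 400 ug/mL in this assay, at which 3 of the 4 values shown sit.

Going by these compounds, how far the true values of compound 1, compound 2 and compound 3 lie from compound 4 stays open. So does what a carboxylic acid or a primary amine would give on this ring carbon.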